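Series notes: sulfonamide nitrogen substituent, dihydroindenyl to fluorophenyl

The source may report more compounds than this note shows. Statements on the series, on what has been measured and on what is new or still open speak of the compounds shown alone.

Measured so far:
compound 1, `CC(C)CN(C1CCc2ccc(F)cc21)S(=O)(=O)c1ccc2c(c1)C(=O)CC(C1CCOCC1)O2`: 4.03
compound 2, `CCc1ccc(N(CC(C)C)S(=O)(=O)c2ccc3oc(C4CCOCC4)cc(=O)c3c2)cc1`: 4.5

In a physicochemical assay for lipophilicity, at pH 7.4 (a higher number here means a more lipophilic compound, a lower number a more polar compound), compound 1 stands lowest of the two numbers, with compound 2 the nearest at a value that lies beyond the scatter above it. Compound 3, `CC(C)CN(c1ccc(F)cc1)S(=O)(=O)c1ccc2c(c1)C(=O)CC(C1CCOCC1)O2`, is not yet measured. It differs from compound 1 in one place: 4-fluorophenyl in place of 6-fluoro-2,3-dihydro-1H-inden-1-yl on a sulfonamide nitrogen. Among the measured compounds shown here, no measured pair follows this exact change, so the expected size rests on the change alone. From compound 1 to compound 3 the expected step is a number 0.63 log units lower from compound 1 to compound 3 (beyond the scatter), downward and beyond the scatter. For compound 3 the estimate is 3.4, with a range from 2.9 to 3.9.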

Compound 3, distribution coefficient: 3.48
Beside the measured number, compound 3's estimate is 0.08 log units below it, within the range that was stated.
By their numbers in this assay, from the lowest: compound 3; then compound 1; then compound 2.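

In this assay the sulfonamide nitrogen proves sensitive to its aromatic substituent: 4-fluorophenyl in place of 6-fluoro-2,3-dihydro-1H-inden-1-yl gives a number 0.55 log units lower from compound 1 to compound 3 (beyond the scatter). Among the compounds shown here, this is the only step read at this position, and it shows that the number moves beyond the scatter when the five-membered non-aromatic ring leaves and the fluorinated aromatic ring stays. No measurement bears on the cause of this step. Open, as far as these compounds go, is how the number moves with an amine or a carboxylic acid on the 4-fluorophenyl ring, and whether the same change on another core gives a similar step.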